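Swapping Hydroxy for Chloro: Vero Cell Cytotoxicity

The compounds below may be only part of what the source reports. "The series", "measured", "known", "first", "only" and "open" are said of these compounds alone.

Measured so far:
compound 1 `O=C1CSC(c2ccc(O)cc2)N1CCN1CCCCC1` — 96%
compound 2 `COc1ccccc1C1SCC(=O)N1CCN1CCCCC1` — 100%

Both numbers come from an ADME assay on Vero cells (Chlorocebus sabaeus) for cytotoxicity, read by neutral red uptake, tested at 49 ug/mL; on this read-out higher numbers stand for a weaker effect at the one concentration tested and lower numbers for a stronger effect. Compound 1 stands alongside compound 2; the gap between the two lies within the usual scatter, so neither can be called the weaker or the stronger. Compound 3 `O=C1CSC(c2ccc(Cl)cc2)N1CCN1CCCCC1` has not yet been measured. Relative to compound 1 it carries chloro in place of hydroxy on an aromatic carbon. Among the compounds with values here, no measured pair shows this change, so there is no step to lean on. The step expected in this assay is a number 6 percentage points lower from compound 1 to compound 3 (within the scatter), a shift toward a somewhat stronger effect that need not exceed the scatter. Compound 3 is therefore estimated at 90%, within 65% to 100%.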

Compound 3, a percentage reported as activity, at one concentration (the size of the read-out at that concentration, not a potency): 84%
Compound 3: middle estimate off by 6 percentage points, on the high side; low and high end bracket the measured number.
By their numbers in this assay, from the lowest: compound 3; then compounds 1 and 2 (each within the scatter of the next).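

Chloro in place of hydroxy on an aromatic carbon, para to a large group, is the first change at this position that can be read in this assay and it gives a number 12 percentage points lower from compound 1 to compound 3 (beyond the scatter) toward a stronger effect at the one concentration tested. Within the data shown here, this position therefore has a measurable influence on the read-out, which the earlier compounds could not show. Nothing measured here accounts for the shift. On these data alone, whether fluoro or an amine in the same place would move the number as far remains open. As far as these compounds go, how this step would look at other concentrations also remains open.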